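The compounds below may be only part of what the source reports. "The series", "measured", "known", "first", "only" and "open" are said of these compounds alone.

Measured so far in a functional assay on U-251 cells (Homo sapiens) for inhibition, read by sulforhodamine B assay, with a stated time of 48 h; on this read-out lower numbers stand for stronger inhibition of growth and higher numbers for weaker inhibition of growth:

Compound 1, `C=C(C)[C@@H]1CC=C(Cn2cc(COc3ccc(C4NC(=O)NC(C)=C4C(=O)OCC)cc3)nn2)CC1`: compound 1 gives 12400 nM.
Compound 2, `C=C(C)[C@@H]1CC=C(Cn2cc(COc3ccccc3C3NC(=O)NC(C)=C3C(=O)OCC)nn2)CC1`: for compound 2 this assay reports only a limit, > 100000 nM.
Compound 3, `C=C(C)[C@@H]1CC=C(Cn2cc(COc3ccc(C4NC(=O)NC(C)=C4C(C)=O)cc3)nn2)CC1`: compound 3 gives 20000 nM.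

Compound 1 and compound 2 have the same atoms joined differently; the difference between the two cores is not broken down here. Compound 3 carries the change methyl in place of ethoxy on a carbonyl carbon against compound 1, and the measured step is a 1.6-fold higher number from compound 1 to compound 3 (0.21 log units; within the scatter).

Compound 4, `C=C(C)[C@@H]1CC=C(Cn2cc(COc3ccccc3C3NC(=O)NC(C)=C3C(C)=O)nn2)CC1`, is not yet measured. Against compound 2 it carries the change (methyl in place of ethoxy on a carbonyl carbon), the same change as from compound 1 to compound 3, at a place described in identical words. Going by the values given here, the one measured instance of this change left the read-out essentially unmoved, so no gain is expected from it here either. Because compound 2 sits at the limit of > 100000 nM in this assay, at which 1 of the 3 values shown sits, the starting point for compound 4 is itself only a limit, and the expected step from compound 2 to compound 4 is a step that the limit leaves unreadable from compound 2 to compound 4. For compound 4 the estimate in this assay is 150000 nM, with a range from 60000 nM to 400000 nM, and most likely the assay will again report only a limit.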

Compound 4, concentration for total growth inhibition: 30200 nM
Estimate against measurement, compound 4: 5.0-fold (0.70 log units) above; the whole stated range lies above it.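

Methyl in place of ethoxy on a carbonyl carbon does not carry over from one core to the other as a single fixed step in this assay: the same change on two cores in this assay, a 1.6-fold higher number (0.21 log units; within the scatter) from compound 1 to compound 3 and an at least 3.3-fold lower number (0.51 log units; beyond the scatter) from compound 2 to compound 4, at least 5.3-fold (0.72 log units) apart, beyond the scatter of two such steps. On the core of compound 2, the change gives an at least 3.3-fold lower number from compound 2 to compound 4 (0.51 log units; beyond the scatter), whereas on the core of compound 1 it leaves the read-out within the scatter. Going by these compounds, for compound 2 the value > 100000 nM is a limit of the assay and not a number, so the true size of this step remains unknown, and a single pair on each core gives no rule for any further core.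

The compounds shown leave open whether other groups on this carbonyl carbon, such as a carboxylic acid, an amide or a longer chain such as butoxy, would also behave differently on the two cores. They also leave open whether the gap between the two steps would hold if compound 2 were given a measured number rather than a limit.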